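Replacing Isopropyl with 4-Aminobutyl in an Oral Tail Flick Series

A few compounds are considered here, and "the series" means these few. Any claim that something is new, unique, unknown or untested is made for them only; others in the source may bear on it.

Compound 1 `NC(=O)CC[C@H](NC(=O)CN(c1ncnc2c1ncn2C1CCCCO1)C1CC1)C(=O)OCc1ccccc1` gives 39.4% in a functional assay on the whole organism (Tail, strain ICR) with Mus musculus as the target, in the tail flick test, with a stated time of 60 min, at a dose of 25 umol/kg by the oral route; on this read-out lower numbers stand for a weaker effect and higher numbers for a stronger effect at the one dose given. Compound 2 `CC(C)[C@H](NC(=O)CN(c1nc(Cl)nc2[nH]cnc12)C1CC1)C(=O)OCc1ccccc1` gives 55.5% in this assay, the higher of the two numbers, and its gap to compound 1 lies beyond the usual scatter. Compound 3 `NCCCC[C@H](NC(=O)CN(c1nc(Cl)nc2[nH]cnc12)C1CC1)C(=O)OCc1ccccc1` is not yet measured; it differs from compound 2 by 4-aminobutyl in place of isopropyl on a saturated chain carbon bound to an amide-type nitrogen and a carbonyl carbon. Among the compounds with values here, no measured pair shows this kind of change, so only a modest step, expected slightly downward in this assay, is estimated: a number 10.5 percentage points lower from compound 2 to compound 3 (beyond the scatter). Compound 3 is therefore expected to give about 45%, within a range from 20% to 70%.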

Compound 3, a percentage reported as activity, at one dose (the size of the read-out at that dose, not a potency): 41.2%
Beside the measured number, compound 3's estimate is 3.8 percentage points above it, and the stated range covers the measured number.
By their numbers in this assay, from the lowest: compounds 1 and 3 (each within the scatter of the next); then compound 2.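

On a saturated chain carbon bound to an amide-type nitrogen and a carbonyl carbon, the group matters: in this assay, 4-aminobutyl in place of isopropyl gives a number 14.3 percentage points lower from compound 2 to compound 3 (beyond the scatter). Within the data shown here, this is the first single-place comparison available, so it shows that the longer, nitrogen-bearing chain gives a weaker effect at this one dose than isopropyl does. Whether chain length or the amine accounts for the step stays open, and a plain butyl chain at this carbon would help separate the two. Nothing measured here gives a reason for the step.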